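The source may report more compounds than this note shows. Statements on the series, on what has been measured and on what is new or still open speak of the compounds shown alone.

Measured compounds and their values in an ADME assay on MT2 cells (Homo sapiens) for cytotoxicity, read by MTT assay; on this read-out lower numbers stand for higher toxicity in this test and higher numbers for lower toxicity in this test:

compound 1, `Fc1cccc(F)c1Cc1cnc(Nc2ccc(Oc3cccnc3)c(Cl)c2)o1`: 16000 nM
compound 2, `Fc1cccc(F)c1Cc1cnc(Nc2ccc(Oc3ccncc3)c(Cl)c2)o1`: 21000 nM
compound 3, `Fc1cccc(F)c1Cc1cnc(Nc2ccc(-c3cccnc3)c(Cl)c2)o1`: 8900 nM

Among these three numbers compound 1 stands second highest. Its nearest neighbour is compound 2, with a 1.3-fold higher number from compound 1 to compound 2 (0.12 log units; within the scatter), and its furthest is compound 3, with a 1.8-fold lower number from compound 1 to compound 3 (0.25 log units; within the scatter); both of these gaps sit inside the usual scatter, so the three compounds cannot be ranked against each other on this read-out with confidence. Within the data shown here, the one step that reaches beyond the scatter is a 2.4-fold lower number from compound 2 to compound 3 (0.37 log units; beyond the scatter), and it is modest.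

Compound 4, `Fc1cccc(F)c1Cc1cnc(Nc2ccc(Oc3cccnc3)c(Br)c2)o1`, differs from compound 1 in one place: bromo in place of chloro on an aromatic carbon.

Among the measured compounds shown here, none of the measured steps touches this position. Each of them alters the group attached through oxygen or the pyridyl ring itself, and even those changes moved the numbers only slightly. For the measured compounds named here, the swap of one halogen for another on the same aromatic carbon, with no change in ring count, donors or acceptors, therefore has no direct precedent here, and nothing in the data points to a shift in either direction beyond the scatter.

The expectation for compound 4 in this assay is a value close to that of compound 1, estimated at 16000 nM, with a range from 8000 nM to 32000 nM. This estimate corresponds to no change at the digits printed from compound 1 to compound 4 (within the scatter), which is expected to fall within the scatter.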

Compound 4, half-maximal cytotoxic concentration: 7500 nM
Estimate against measurement, compound 4: 2.1-fold (0.33 log units) above; the whole stated range lies above it.
By their numbers in this assay, from the lowest: compounds 4, 3, 1 and 2 (each within the scatter of the next, the first and the last beyond it).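

In this assay, the aromatic carbon that carries the halogen proves able to move the number: with bromo in place of chloro there is a 2.1-fold lower number from compound 1 to compound 4 (0.33 log units; beyond the scatter), a modest step but one toward higher toxicity in this test. Among these compounds, the earlier compounds all keep chloro here, and the changes they make elsewhere from compound 1, a 1.3-fold higher number from compound 1 to compound 2 (0.12 log units; within the scatter) and a 1.8-fold lower number from compound 1 to compound 3 (0.25 log units; within the scatter), stay inside the usual scatter, so this halogen swap is the first change from compound 1 to pass beyond it. No measurement at hand bears on why the number moves with this swap.

With only chloro and bromo shown on this carbon, it remains open whether a fluoro, methyl or methoxy group there would give a lower number, a higher one, or no clear change. As far as these compounds go, it is also open whether the same swap from chloro to bromo would produce a step of similar size and direction on compound 2 or compound 3, whose pyridine-bearing groups differ from that of compound 1.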